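Pyrazin-2-yl in place of pyridin-2-yl: expected shift

The compounds below may be only part of what the source reports. "The series", "measured", "known", "first", "only" and "open" are said of these compounds alone.

Among the compounds with values here, compound 3 `Cc1ncc(CO)c2c(Nc3ccccn3)c(NCc3ccccc3)oc12` gives 4910 nM in a functional assay on HEK293 cells for agonist activity at Toll-like receptor 8 (Homo sapiens), read by reporter gene assay (a higher number here means that more compound is needed for the effect, a lower number that less compound is needed), the highest of the two numbers so far. Within the data shown here, its nearest neighbour, compound 1 `Cc1ncc(CO)c2c(Nc3ccccc3)c(NCc3ccccc3)oc12`, gives 1680 nM in this assay, and the single measured step, a 2.9-fold higher number from compound 1 to compound 3 (0.47 log units; beyond the scatter), is modest but beyond the scatter. Compound 2 `CCOC(=O)CNc1oc2c(C)ncc(CO)c2c1Nc1ccccn1` is reported in this assay as "not active" (no number reported), with no number.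

Compound 4 `Cc1ncc(CO)c2c(Nc3cnccn3)c(NCc3ccccc3)oc12` differs from compound 3 by pyrazin-2-yl in place of pyridin-2-yl on a nitrogen on an aromatic ring. Among the measured compounds shown here, the only step that bears on this change is a 2.9-fold higher number from compound 1 to compound 3 (0.47 log units; beyond the scatter), where pyridin-2-yl replaced phenyl on the same nitrogen and the number rose. The present change puts two hetero atoms in the ring where there was one, so a further rise of similar size, or none beyond the scatter, is the expectation; the reported absence of a number for compound 2 leaves open that compound 4 also gives only a limit. Compound 4 is estimated at 9000 nM, within 3000 nM to 30000 nM, which means an expected step of a 1.8-fold higher number from compound 3 to compound 4 (0.26 log units; within the scatter).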

Compound 4, half-maximal effective concentration: 9790 nM
Estimate against measurement, compound 4: 1.1-fold (0.04 log units) below; low and high end bracket the measured number.
By their numbers in this assay, from the lowest: compound 1; then compounds 3 and 4 (each within the scatter of the next).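

In this assay the step of a 2.0-fold higher number from compound 3 to compound 4 (0.30 log units; within the scatter) lies within the scatter, so on this nitrogen pyrazin-2-yl, a ring with 2 hetero atoms, cannot be told apart from pyridin-2-yl, a ring with 1 hetero atom. Against phenyl the reading differs: the step of a 5.8-fold higher number from compound 1 to compound 4 (0.77 log units; beyond the scatter) is beyond the scatter and runs the same way as the step of a 2.9-fold higher number from compound 1 to compound 3 (0.47 log units; beyond the scatter), so both rings with hetero atoms on this nitrogen need more compound than phenyl. No measured evidence here accounts for these steps.

On these data alone, what remains open is whether any group on this nitrogen, for instance a phenyl ring carrying methoxy or chlorine, gives a smaller number than compound 1, which stands at 1680 nM. As far as these compounds go, it is also open whether the phenyl preference holds when the benzyl on the other nitrogen is replaced by a longer alkyl chain.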